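The compounds below may be only part of what the source reports. "The series", "measured", "known", "first", "only" and "open" are said of these compounds alone.

Compound 1 `CCCCCC(CCO)n1cnc2c(N)nc(Cl)nc21`: > 50000 nM, a limit
Compound 2 `CCCCCCCC(CCO)n1cnc2c(Cl)nc(Cl)nc21`: 12800 nM
Compound 3 `CCCCCCCC(CCO)n1cnc2c(N)ncnc21`: > 50000 nM, a limit

These results come from a functional assay on HCT-116 cells (Homo sapiens) for antiproliferative activity, read by MTT assay, with a stated time of 48 h (on this read-out lower numbers stand for stronger inhibition and higher numbers for weaker inhibition), where only compound 2 has a measured number. Compound 3 has only a limit, > 50000 nM. That is the limit of > 50000 nM in this assay, at which 2 of the 3 values shown sit.

Compound 4 `CCCCCCCC(CCO)n1cnc2c(N)nc(Cl)nc21` differs from compound 3 by a single change: chloro in place of hydrogen on an aromatic carbon. Going by the values given here, no measured pair shows this change alone, so its size must be judged indirectly. Compound 1, which also carries this chloro, has only a limit, > 50000 nM. Compound 2 gives 12800 nM, and this number suggests that some measurable activity is possible. A modest move toward stronger inhibition is expected, estimated as an at least 1.6-fold lower number from compound 3 to compound 4 (0.22 log units; that floor lies within the scatter). The estimate for compound 4 is 30000 nM, with an expected range of 12000 nM to 60000 nM.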

Compound 4, half-maximal inhibitory concentration: > 50000 nM
Compound 4 ended at the assay's limit; the forecaster's own chance of this, stated with the estimate: 45%; at least 1.6-fold (0.22 log units) between middle value and limit.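

Amino in place of chloro on an aromatic carbon gives an at least 3.9-fold higher number from compound 2 to compound 4 (0.59 log units; beyond the scatter) in this assay, so among these compounds only compound 2, which has no amino group, reaches a measured number. Chloro on the carbon between two ring nitrogen atoms does not bring compound 3 to a measured number in compound 4. The steps to compound 4 from compound 3 and from compound 1 cannot be read, as each joins two limits: the limit of > 50000 nM in this assay, at which 3 of the 4 values shown sit.

From the compounds shown here alone, whether a methoxy group or a methylamino group in place of that amino would keep the activity of compound 2 remains open.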